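The source may report more compounds than this note shows. Statements on the series, on what has been measured and on what is new or still open speak of the compounds shown alone.

Measured compounds:
compound 1, `C#CCN(CCCCOc1ccc2ccc(=O)oc2c1)Cc1ccc(OC)cc1`: 54500 nM
compound 2, `C#CCN(CCCCOc1ccc2ccc(=O)oc2c1)Cc1cccc(F)c1`: 69200 nM
compound 3, `C#CCN(CCCCOc1ccc2ccc(=O)oc2c1)Cc1ccccc1`: 89400 nM

In an ADME assay on isolated protein for inhibition of Amine oxidase [flavin-containing] A (Homo sapiens), read by fluorescence and Amplex Red, with stated times of 15 min and 20 min (a higher number here means a weaker inhibitor, a lower number a stronger inhibitor), compound 3 differs from compound 2 and from compound 1 by less than the scatter, so all three stand together as weak inhibitors. Compound 4 `C#CCN(C)CCCCOc1ccc2ccc(=O)oc2c1` differs from compound 3 by hydrogen in place of phenyl on a saturated chain carbon bound to an amine nitrogen. For the measured compounds named here, no measured step removes that ring: the steps of a 1.3-fold higher number from compound 1 to compound 2 (0.10 log units; within the scatter), a 1.6-fold higher number from compound 1 to compound 3 (0.21 log units; within the scatter) and a 1.3-fold higher number from compound 2 to compound 3 (0.11 log units; within the scatter) only alter what sits on the ring, and each stays within the scatter. Losing the whole ring is a larger change than any of these, so a modest move either way in this assay cannot be excluded, but nothing points clearly in one direction. Compound 4 is therefore expected near 100000 nM, with a range from 30000 nM to 350000 nM. That estimate means an expected step of a 1.1-fold higher number from compound 3 to compound 4 (0.05 log units; within the scatter), not beyond the scatter.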

Compound 4, half-maximal inhibitory concentration: 3280 nM
Beside the measured number, compound 4's estimate is 30-fold (1.48 log units) above it, outside the stated range (below it).
By their numbers in this assay, from the lowest: compound 4; then compounds 1, 2 and 3 (each within the scatter of the next).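

In this assay, the benzyl group as a whole matters far more than what it carries: replacing it with methyl gives large steps (a 27-fold lower number from compound 3 to compound 4 (1.44 log units; beyond the scatter)), (a 21-fold lower number from compound 2 to compound 4 (1.32 log units; beyond the scatter)) and (a 17-fold lower number from compound 1 to compound 4 (1.22 log units; beyond the scatter)). All three benzyl compounds move by a similar large amount, so the ring substituents seen here do not rescue the loss. Nothing available explains why removing the ring has so large an effect.

The compounds shown leave open how much size this position tolerates. An ethyl or propyl chain in place of methyl could show whether the number stays near that of compound 4 or climbs towards those of the benzyl compounds.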